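5-HT6 sulfonamide series: aryl swap on the sulfonamide nitrogen

The source may hold more compounds than are shown below. What is called first, only, known or untested is meant among the compounds shown, and "the series" means these compounds.

Measured compounds in an assay on isolated protein for binding affinity to 5-hydroxytryptamine receptor 6 (Homo sapiens); on this read-out lower numbers stand for stronger inhibition and higher numbers for weaker inhibition:
- compound 1 `COc1ccc(S(=O)(=O)Nc2cc(Cl)cc(Cl)c2)cc1N1CCNCC1`: 0.631 nM
- compound 2 `COc1ccc(S(=O)(=O)Nc2ccc(C)cc2Br)cc1N1CCNCC1`: 7.94 nM
- compound 3 `COc1cc(Cl)c(C)cc1NS(=O)(=O)c1ccc(OC)c(N2CCNCC2)c1`: 2 nM

Compound 2 stands highest of the three numbers; its nearest neighbour is compound 3 at 2 nM, and the furthest is compound 1 at 0.631 nM, both gaps beyond the scatter.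

The unmeasured compound 4 `COc1ccc(S(=O)(=O)Nc2cc(Cl)cc(Br)c2Cl)cc1N1CCNCC1` differs from compound 2 in one place: 3-bromo-2,5-dichlorophenyl in place of 2-bromo-4-methylphenyl on a sulfonamide nitrogen.

Within the data shown here, only one measured step touches this position. Going from the 3,5-dichlorophenyl of compound 1 to the 2-bromo-4-methylphenyl of compound 2 gave a 13-fold higher number from compound 1 to compound 2 (1.10 log units; beyond the scatter). Compound 4 carries a 3-bromo-2,5-dichlorophenyl, so it returns to a halogen-only ring with substituents at the 3 and 5 positions, as in compound 1, while adding a chlorine at the 2 position, for which no comparison exists here. Among the measured compounds shown here, the single relevant step therefore points to a move back toward compound 1, most likely smaller than the full reversal given the extra chlorine. For compound 4 the step of a 5.3-fold lower number from compound 2 to compound 4 (0.72 log units; beyond the scatter) is expected, placing compound 4 at an estimated 1.5 nM in this assay, within a range of 0.5 nM to 5 nM.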

Compound 4, inhibition constant: 2 nM
Beside the measured number, compound 4's estimate is 1.3-fold (0.12 log units) below it; the measured number falls inside the stated range.
By their numbers in this assay, from the lowest: compound 1; then compounds 3 and 4 (each within the scatter of the next); then compound 2.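

In this assay, replacing the aryl group on the sulfonamide nitrogen with 3-bromo-2,5-dichlorophenyl gives a 4.0-fold lower number from compound 2 to compound 4 (0.60 log units; beyond the scatter) and also a 3.2-fold higher number from compound 1 to compound 4 (0.50 log units; beyond the scatter) so this group places compound 4 between the other two aryl variants. The earlier step showed only a loss on leaving the 3,5-dichlorophenyl of compound 1; this result shows that part of that loss can be recovered with a ring bearing halogens alone, while three halogens in this arrangement do not match the two chlorines of compound 1. No data shown give a reason for these shifts.

Compared with compound 1, compound 4 differs in both an added chlorine and a bromine in place of a chlorine, so the share of each in the change remains unresolved without a compound carrying only one of these differences. On these data alone, it also remains open how this position responds to a group of another kind on the ring, such as a nitrile, a trifluoromethyl, an amine or a carboxylic acid.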